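The compounds below may be only part of what the source reports. "The series", "measured", "known", "first", "only" and "open" are said of these compounds alone.

Values in a functional assay on MV4-11 cells (Homo sapiens) for inhibition, read by resazurin assay, with a stated time of 72 h; a higher number here means a weaker inhibitor of growth, a lower number a stronger inhibitor of growth:
- compound 1 `O=C1NCCC12CCN(c1c(Cl)cncc1-c1ccsc1)CC2`: 190 nM
- compound 2 `O=C1NCCC12CCN(c1c(Cl)cncc1-c1cc[nH]c1)CC2`: 1050 nM
- compound 3 `Cc1ccsc1-c1cncc(Cl)c1N1CCC2(CCNC2=O)CC1`: 910 nM
- compound 4 `Cc1ccc(-c2cncc(Cl)c2N2CCC3(CCNC3=O)CC2)s1`: not yet measured

Compound 3 cannot be told apart from compound 2, with a 1.2-fold lower number from compound 2 to compound 3 (0.06 log units; within the scatter). Compound 1 holds the lowest number, with a 5.5-fold higher number from compound 1 to compound 2 (0.74 log units; beyond the scatter) and a 4.8-fold higher number from compound 1 to compound 3 (0.68 log units; beyond the scatter).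

Compound 4 has the same atoms as compound 3, joined differently: 5-methylthiophen-2-yl in place of 3-methylthiophen-2-yl on an aromatic carbon. Here 5-methylthiophen-2-yl stands in place of 3-methylthiophen-2-yl, on an aromatic carbon ortho to a large group.

Among the measured compounds shown here, no measured step isolates this kind of change. The closest is a 4.8-fold higher number from compound 1 to compound 3 (0.68 log units; beyond the scatter), which exchanges thiophen-3-yl for 3-methylthiophen-2-yl, and it alters the point of attachment and the methyl group together. It suggests only that part of that gap might be recovered, so the direction is uncertain.

The expected change in this assay is small and towards a lower number, probably not clearly beyond the scatter: a 1.8-fold lower number from compound 3 to compound 4 (0.26 log units; within the scatter). Compound 4 is estimated at 500 nM, with an expected range from 170 nM to 1400 nM.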

Compound 4, concentration for 50% growth inhibition: 650 nM
Estimate against measurement, compound 4: 1.3-fold (0.11 log units) below; the measured number falls inside the stated range.
By their numbers in this assay, from the lowest: compound 1; then compounds 4, 3 and 2 (each within the scatter of the next).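

In this assay, moving the methyl group from 3-methylthiophen-2-yl to 5-methylthiophen-2-yl on this aromatic carbon, ortho to a large group, gives a 1.4-fold lower number from compound 3 to compound 4 (0.15 log units; within the scatter), so this pair does not resolve any effect of where the methyl sits on the thiophene. Compound 4 also stays within the scatter of the 1H-pyrrol-3-yl compound, with a 1.6-fold lower number from compound 2 to compound 4 (0.21 log units; within the scatter), while a 3.4-fold higher number from compound 1 to compound 4 (0.53 log units; beyond the scatter) shows that the gap to the thiophen-3-yl of compound 1 persists with the methyl group at the 5-position as well as at the 3-position. No available evidence accounts for these results.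

The compounds shown leave open whether that gap follows from the point of attachment or from the methyl group, a question that unsubstituted thiophen-2-yl would separate. From the compounds shown here alone, how a phenyl ring or a thiophene carrying an aminomethyl group would read out at this position also remains open.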